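A few compounds are considered here, and "the series" means these few. Any claim that something is new, unique, unknown or untested is made for them only; others in the source may bear on it.

Three compounds have been measured in an assay on HeLa cells with Bile acid receptor (Homo sapiens) as the target, read by a luciferase reporter, with a stated time of 24 h; a higher number here means that more compound is needed for the effect, a lower number that less compound is needed:

Compound 1, `CC(NC(=O)c1ccc(C(C)(C)C)cc1)c1ccc(C(=O)O)cc1`, gives 76 nM
Compound 2, `CC(=O)c1ccc(CNC(=O)c2ccc(C(C)(C)C)cc2)cc1`, gives 100 nM
Compound 3, `O=C(O)c1ccc(CNC(=O)c2ccc(-c3ccccc3)cc2)cc1`, gives 440 nM

Compound 2 stands second highest of these three numbers. Its value and that of compound 1 lie within the usual scatter of each other, so nothing can be said about their order. Among the measured compounds shown here, compound 3 gives a number well beyond the scatter above that of compound 2, and is the one measured compound that needs clearly more material in this assay.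

Compound 4, `CC(C)(C)c1ccc(C(=O)NCc2ccc(NS(C)(=O)=O)cc2)cc1`, has not yet been measured. It differs from compound 2 in one place: methanesulfonamido in place of acetyl on an aromatic carbon. For the measured compounds named here, no step between two measured compounds isolates this change, so the account rests on the structural change alone. Because compound 2 gives 100 nM with the acetyl in place, compound 4 is expected to land close to it, with a step from compound 2 to compound 4 of a 1.5-fold higher number from compound 2 to compound 4 (0.18 log units; within the scatter) in this assay that is estimated to stay within the scatter. The estimated value for compound 4 is 150 nM, with a range from 50 nM to 500 nM.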

Compound 4, half-maximal effective concentration: 44 nM
The estimate for compound 4 lay 3.4-fold (0.53 log units) above the measured number, outside the stated range (below it).
By their numbers in this assay, from the lowest: compounds 4, 1 and 2 (each within the scatter of the next, the first and the last beyond it); then compound 3.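

In this assay, among the compounds shown here, the swap of acetyl for methanesulfonamido on this aromatic carbon, para to a large group, gives the first step that isolates a single change (a 2.3-fold lower number from compound 2 to compound 4 (0.36 log units; beyond the scatter)). It shows that this position accepts a larger group carrying a hydrogen-bond donor, which acetyl lacks, and that the number falls beyond the scatter rather than rises. Nothing measured here accounts for this fall.

The compounds shown leave open whether the hydrogen-bond donor matters, which a methylated sulfonamide nitrogen or a plain amine at this position could test, and whether a longer chain on the sulfonyl group is accepted. They also leave open whether methanesulfonamido would give a similar step on the core of compound 1 or compound 3.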